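The compounds below may be only part of what the source reports. "The series", "measured", "known", "first", "only" and "open" are said of these compounds alone.

Measured so far in a functional assay on WiDr cells (Homo sapiens) for inhibition, read by sulforhodamine B assay, with a stated time of 48 h; on this read-out higher numbers stand for weaker inhibition of growth and lower numbers for stronger inhibition of growth:
compound 1, `O=C(/C(=C/c1ccccc1)CCl)c1ccccc1`: 18000 nM
compound 2, `O=C(/C(=C/c1ccc(Cl)cc1)CCl)c1ccccc1`: 19000 nM
compound 3, `CC(=O)OC/C(=C/c1ccccc1Cl)C(=O)c1ccccc1`: 22000 nM

Compound 2 comes from compound 1 by one change, (chloro in place of hydrogen on an aromatic carbon). That step, a 1.1-fold higher number from compound 1 to compound 2 (0.02 log units; within the scatter), left the growth inhibition where it was. Compound 4, `CC(=O)OC/C(=C/c1ccc(Cl)cc1Cl)C(=O)c1ccccc1`, is not yet measured; it comes from compound 3 by the same kind of change, (chloro in place of hydrogen on an aromatic carbon). The surroundings differ somewhat: here the new chloro sits meta to a chloro group as well as para to a large group. How the core of compound 3 differs from that of compound 1 is not broken down here; the two cores sit close in this assay. Because compound 1 to compound 2 gave a 1.1-fold higher number from compound 1 to compound 2 (0.02 log units; within the scatter), compound 4 is expected to show a similar step, a 1.0-fold lower number from compound 3 to compound 4 (0.02 log units; within the scatter). The estimate for compound 4 is therefore 21000 nM, between 10000 nM and 42000 nM.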

Compound 4, concentration for 50% growth inhibition: 19000 nM
Compound 4: the middle estimate sits 1.1-fold (0.04 log units) above what was measured; low and high end bracket the measured number.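

In this assay, the added chloro gave a 1.2-fold lower number from compound 3 to compound 4 (0.06 log units; within the scatter), so this change again left growth inhibition where it was. The two steps agree across the two cores: the same change on two cores in this assay, a 1.1-fold higher number (0.02 log units; within the scatter) from compound 1 to compound 2 and a 1.2-fold lower number (0.06 log units; within the scatter) from compound 3 to compound 4, 1.2-fold (0.09 log units) apart, within the scatter of two such steps. This shows that the chloro change made no measurable difference on either core, but since neither step moved the number, it does not show that a real effect would carry from one core to another.

As far as these compounds go, it remains open whether a different group on the aromatic ring, such as an amine or a carboxylic acid, would shift growth inhibition. From the compounds shown here alone, it is also open whether the result would hold on a core carrying a longer chain.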